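Extending the saturated chain on the shared core

The compounds below may be only part of what the source reports. "The series", "measured", "known", "first", "only" and "open" are said of these compounds alone.

Among the compounds with values here, compound 2 `Cc1nc(N)sc1CCCN/C(N)=N/C(=O)NCc1ccccc1` carries a phenyl on a saturated chain carbon bound to an amide-type nitrogen; in an assay on membranes from Sf9 cells for displacement of a labelled ligand from histamine H2 receptor (Homo sapiens), read by scintillation counting, with a stated time of 60 min (on this read-out lower numbers stand for stronger inhibition and higher numbers for weaker inhibition), compound 2 gives 69.2 nM, the highest of the two numbers so far. Its nearest neighbour is compound 1 `Cc1nc(N)sc1CCCN/C(N)=N/C(=O)NCC(C)C1CCCCC1`, which in this assay gives 39.8 nM; the step of a 1.7-fold higher number from compound 1 to compound 2 (0.24 log units; within the scatter) stays within the scatter. Compound 3 `Cc1nc(N)sc1CCCN/C(N)=N/C(=O)NCC(C)CC1CCCCC1` differs from compound 2 in one place: 1-(cyclohexylmethyl)ethyl in place of phenyl on a saturated chain carbon bound to an amide-type nitrogen. Within the data shown here, only that single step bears on the change, and it was small, so for compound 3 a modest step of a 1.7-fold lower number from compound 2 to compound 3 (0.24 log units; within the scatter) toward a lower number is expected, with compound 3 estimated at 40 nM in this assay, within a range from 15 nM to 110 nM.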

Compound 3, inhibition constant: 70.8 nM
Estimate against measurement, compound 3: 1.8-fold (0.25 log units) below, and the stated range covers the measured number.
By their numbers in this assay, from the lowest: compounds 1, 2 and 3 (each within the scatter of the next).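

In this assay, phenyl and 1-(cyclohexylmethyl)ethyl on a saturated chain carbon bound to an amide-type nitrogen are not told apart, with a 1.0-fold higher number from compound 2 to compound 3 (0.01 log units; within the scatter) despite the loss of the aromatic ring. Cyclohexylmethyl in place of cyclohexyl on a saturated chain carbon bound to two saturated chain carbons likewise gives a 1.8-fold higher number from compound 1 to compound 3 (0.25 log units; within the scatter), so all three compounds lie within the scatter of one another. No evidence is available to explain this result. As far as these compounds go, whether an amine or a carboxylic acid in place of these groups would give a number beyond the scatter remains open.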